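The compounds below may be only part of what the source reports. "The series", "measured", "known", "first", "only" and "open" are said of these compounds alone.

Measured in a functional assay on RS4-11 cells (Homo sapiens) for inhibition, read by CCK-8 assay, with a stated time of 48 h, tested at 20 uM; a higher number here means more inhibition of growth at the concentration tested, a lower number less inhibition of growth:
Compound 1 `N#C/C(=C\c1ccccc1OS(=O)(=O)c1ccc([N+](=O)[O-])cc1)C(=O)Nc1nnc(Cc2cccc3ccccc23)s1`: 58%
Compound 2 `N#C/C(=C\c1ccccc1OS(=O)(=O)c1ccccc1[N+](=O)[O-])C(=O)Nc1nnc(Cc2cccc3ccccc23)s1`: 66%
Compound 3 `N#C/C(=C\c1ccccc1OS(=O)(=O)c1ccc(F)cc1)C(=O)Nc1nnc(Cc2cccc3ccccc23)s1`: 68%

Compound 2 does not separate from the other two compounds, as the steps of a number 8 percentage points higher from compound 1 to compound 2 (within the scatter) and a number 2 percentage points higher from compound 2 to compound 3 (within the scatter) show. Compound 4 `N#C/C(=C\c1ccccc1OS(=O)(=O)c1ccccc1[N+](=O)[O-])C(=O)Nc1nnc(Cc2ccccc2)s1` differs from compound 2 by phenyl in place of naphthalen-1-yl on a saturated chain carbon bound to an aromatic carbon. The remaining measured step is a number 10 percentage points higher from compound 1 to compound 3 (within the scatter). None of the three steps touches this group, so they give only an indirect guide, and the data show no direction for this change. A small step is expected in this assay, with no shift beyond the scatter, and the estimated step is a number 8 percentage points lower from compound 2 to compound 4 (within the scatter). The estimate for compound 4 is 58%, with an expected range of 40% to 74%.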

Compound 4, percent growth inhibition at one concentration: 71%
Compound 4: middle estimate off by 13 percentage points, on the low side, and the stated range covers the measured number.
By their numbers in this assay, from the lowest: compounds 1, 2, 3 and 4 (each within the scatter of the next, the first and the last beyond it).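

In this assay, the change from naphthalen-1-yl to phenyl on a saturated chain carbon bound to an aromatic carbon gives a number 5 percentage points higher from compound 2 to compound 4 (within the scatter). This is the first change shown at this place, and losing one of the two aromatic rings leaves no shift that can be told from the scatter in this pair. Nothing at hand accounts for this result.

Still open, from the compounds shown here alone, is whether cyclohexyl, an amine or a longer chain would be tolerated at this place. Also open, going by these compounds, is whether phenyl behaves the same way alongside 4-fluorophenyl on the sulfonyl sulfur.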